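Cytotoxicity at the Limit: Carbamoyl Gives Way to Methoxy

A few compounds are considered here, and "the series" means these few. Any claim that something is new, unique, unknown or untested is made for them only; others in the source may bear on it.

Three ureas built on one shared core have been tested in an ADME assay on Raji cells (Homo sapiens) for cytotoxicity, with a stated time of 72 h; a higher number here means that more compound is needed for the effect, a lower number that less compound is needed: compound 1 `Cc1cc(NC(=O)Nc2ccc(F)cc2)c2ccccc2n1`, compound 2 `Cc1cc(NC(=O)Nc2ccccc2OC(F)(F)F)c2ccccc2n1` and compound 3 `Cc1cc(NC(=O)Nc2ccccc2C(N)=O)c2ccccc2n1`. In this assay compound 1 gives > 25000 nM, which is a limit of the assay and not a number. Compound 2 likewise reaches only a limit, > 25000 nM. Compound 3 also gives only a limit, > 25000 nM. Within the data shown here, the single step between measured neighbours, a step that the two limits leave unreadable from compound 2 to compound 3, cannot be read because the limit of > 25000 nM in this assay, at which 3 of the 3 values shown sit, holds both its ends. Among the measured compounds shown here, compound 3 therefore stands at the limit with no number of its own, and nothing among the measured compounds separates it from compound 1 or compound 2.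

The next compound is compound 4 `COc1ccccc1NC(=O)Nc1cc(C)nc2ccccc12`. Its change from compound 3 is methoxy in place of carbamoyl on an aromatic carbon. For the measured compounds named here, the only measured step that concerns this position, a step that the two limits leave unreadable from compound 2 to compound 3, is unreadable, so no size of step can be taken from the data, in either direction. With every measured compound at the limit, the step that the limit leaves unreadable from compound 3 to compound 4 is expected to be unreadable as well. Compound 4 is thus expected to give about 40000 nM in this assay, between 20000 nM and 100000 nM, most probably reported again only as a limit.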

Compound 4, half-maximal effective concentration: > 25000 nM
Compound 4 ended at the assay's limit; the forecaster's own chance of this, stated with the estimate: 85%; the middle value lies beyond the limit too.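

Neither the comparison of compound 3 with compound 4 nor that of compound 2 with compound 4 yields a readable step in this assay, and every value remains a limit of the assay: the limit of > 25000 nM in this assay, at which 4 of the 4 values shown sit.

The compounds shown leave open how far each of the four lies from that limit, and which change, if any, would give a readable value.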